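Swapping methoxy for nitro on the aryl piperazine arm

This account rests on a few compounds, and the source may have more. Where it says the series, first, only, none or still open, it means among the compounds named here.

Compound 1 `O=C1Nc2ccc(F)cc2/C1=N/NC(=S)N1CCN(c2ccccc2)CC1` gives 20700 nM in a functional assay on A549 cells (Homo sapiens) for inhibition, read by MTT assay, with a stated time of 72 h; a higher number here means a weaker inhibitor, a lower number a stronger inhibitor. Compound 2 `COc1ccc(N2CCN(C(=S)N/N=C3\C(=O)Nc4ccc(Cl)cc43)CC2)cc1` has the lower of the two numbers, with 7680 nM in this assay, a gap to compound 1 that lies beyond the usual scatter. Compound 3 `O=C1Nc2ccc(Cl)cc2/C1=N/NC(=S)N1CCN(c2ccc([N+](=O)[O-])cc2)CC1` is not yet measured; it differs from compound 2 in one place (nitro in place of methoxy on an aromatic carbon). Going by the values given here, no measured pair shows this change, so its effect is unknown here. The step of a 1.0-fold higher number from compound 2 to compound 3 (0.02 log units; within the scatter) is expected to be small, probably within the scatter, in no clear direction. Compound 3 is therefore estimated at 8000 nM, within 2500 nM to 25000 nM.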

Compound 3, half-maximal inhibitory concentration: 11800 nM
For compound 3 the middle estimate is 1.5-fold (0.17 log units) below the measured one, within the range that was stated.
By their numbers in this assay, from the lowest: compounds 2, 3 and 1 (each within the scatter of the next, the first and the last beyond it).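

In this assay, the first pair differing in only one place gives a 1.5-fold higher number from compound 2 to compound 3 (0.19 log units; within the scatter). Replacing 4-methoxyphenyl with 4-nitrophenyl therefore produces no clear change in this read-out, so this position accepts both groups in this one pair. Nothing measured here explains that outcome. As far as these compounds go, it remains open whether an amine or a carboxylic acid on this aromatic carbon would move the number beyond the scatter. From the compounds shown here alone, it is also open whether the swap from methoxy to nitro would read the same on another core.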